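Sulfamoyl urea series: alkoxy in place of diallylamino

A few compounds are considered here, and "the series" means these few. Any claim that something is new, unique, unknown or untested is made for them only; others in the source may bear on it.

Of the compounds shown here, three sharing the core of compound 1 have been measured in an assay on liver for inhibition of sterol O-acyltransferase 1 (Rattus norvegicus), using microsomes; a lower number here means a stronger inhibitor, a higher number a weaker inhibitor. Compound 1 `C=CCN(CC=C)S(=O)(=O)NC(=O)Nc1c(C(C)C)cccc1C(C)C` gives 2700 nM, the highest of the three numbers. Compound 3 `CC(C)c1cccc(C(C)C)c1NC(=O)NS(=O)(=O)N(CC1CCCO1)CC1CCCO1` gives 1700 nM, which lies within the scatter of the value of compound 1. Compound 2 `CC(C)c1cccc(C(C)C)c1NC(=O)NS(=O)(=O)N(C(C)C)C1CCCCC1` gives 360 nM, a lower number than compound 1 by a margin beyond the scatter, so among these three only compound 2 stands apart.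

Compound 4 `CCCCCCC(C)OS(=O)(=O)NC(=O)Nc1c(C(C)C)cccc1C(C)C` has not yet been measured. It differs from compound 1 in one place: (1-methylheptyl)oxy in place of diallylamino on a sulfonyl sulfur. Among the measured compounds shown here, no measured pair shows this kind of change, so nothing directly anchors the size of the step. The only hint that moving away from the diallylamino group can lower the number comes from compound 2, which carries isopropyl and cyclohexyl groups and gives 360 nM. Compound 4 is therefore expected to give a somewhat lower number than compound 1, the expected step of a 2.3-fold lower number from compound 1 to compound 4 (0.35 log units; beyond the scatter) being modest and possibly still within the scatter. The estimate for compound 4 is 1200 nM, with a range from 300 nM to 5000 nM.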

Compound 4, half-maximal inhibitory concentration: 35000 nM
Beside the measured number, compound 4's estimate is 29-fold (1.46 log units) below it; the measured number lies above the stated range.
By their numbers in this assay, from the lowest: compound 2; then compounds 3 and 1 (each within the scatter of the next); then compound 4.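

In this assay, (1-methylheptyl)oxy in place of diallylamino on a sulfonyl sulfur gives a 13-fold higher number from compound 1 to compound 4 (1.11 log units; beyond the scatter) and so weakens inhibition by a large margin. Among the compounds shown here, compounds 1, 2 and 3 all carry a nitrogen-linked group at this position, so this is the first sign that the series is sensitive to an oxygen-linked chain there. Nothing available here explains the size or direction of this step.

This single change replaces both the linking atom and the chain, so the effect of the oxygen link cannot be separated from that of the (1-methylheptyl) chain. An amine bearing the same 1-methylheptyl chain, or a shorter alkoxy group such as isopropoxy, would be needed to separate the two.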